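Triazole Substituent Swap and Aromatase Inhibition

This account rests on a few compounds, and the source may have more. Where it says the series, first, only, none or still open, it means among the compounds named here.

Of the compounds shown here, three built on a shared triazole-bearing core have been measured in an assay on isolated protein for inhibition of Aromatase (Homo sapiens), read by fluorescence and colorimetric assay, with a stated time of 30 min; on this read-out higher numbers stand for weaker inhibition and lower numbers for stronger inhibition. Compound 1 `CCCCCCCCCCc1cn(C(c2ccc(C#N)cc2)c2ccc(C#N)cc2)nn1` gives 16000 nM in this assay. Compound 2 `N#Cc1ccc(C(c2ccc(C#N)cc2)n2cc(COc3ccc(-c4ccccc4)cc3)nn2)cc1` gives 13400 nM in this assay. Compound 3 `CCCc1cn(C(c2ccccc2)c2ccccc2)nn1` gives 11000 nM in this assay. The three numbers lie within the usual scatter of one another, so compound 3 cannot be set apart from compound 1 or compound 2 on these data; all three are weak inhibitors.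

The next compound, compound 4 `Cc1ccc(OCc2cn(C(c3ccccc3)c3ccccc3)nn2)cc1`, differs from compound 3 in one place: 4-methylphenoxy in place of ethyl on a saturated chain carbon bound to an aromatic carbon. Among the compounds with values here, no pair of measured compounds differing in just one place is available, so there is no measured step to lean on. Since compound 2, which also carries an aryloxy-methyl group on the same core, gives 13400 nM in this assay, a large move is not anticipated. The step from compound 3 to compound 4 is expected to be a 1.2-fold lower number from compound 3 to compound 4 (0.09 log units; within the scatter), which is not beyond the scatter. Compound 4 is estimated at 9000 nM in this assay, within a range from 3000 nM to 27000 nM.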

Compound 4, half-maximal inhibitory concentration: 26800 nM
Compound 4: the middle estimate sits 3.0-fold (0.47 log units) below what was measured, and the stated range covers the measured number.
By their numbers in this assay, from the lowest: compounds 3, 2, 1 and 4 (each within the scatter of the next, the first and the last beyond it).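

In this assay, within the data shown here, the swap of ethyl for 4-methylphenoxy, on a saturated chain carbon bound to an aromatic carbon, is the only one-place change available, and it gives a 2.4-fold higher number from compound 3 to compound 4 (0.39 log units; beyond the scatter) and so a modest weakening of inhibition. This shows that the position does respond to what is placed on it, even though all the compounds remain weak inhibitors. Adding an aromatic ring and an oxygen here brings no gain, and nothing available identifies which part of the larger group accounts for the weakening.

Still open, as far as these compounds go, is whether a smaller group at this position, such as methyl, or a group of a different kind, such as an amine or a carboxylic acid, would restore or improve inhibition. Also open, from the compounds shown here alone, is whether the same swap would have a similar effect on a core carrying the two nitrile groups.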